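Swapping Bromo for Methoxy: Compound 1 to Compound 4

The compounds below may be only part of what the source reports. "The series", "measured", "known", "first", "only" and "open" are said of these compounds alone.

Of the compounds shown here, three have so far been measured in a functional assay on HCT-116 cells (Homo sapiens) for cytotoxicity, with a stated time of 72 h; on this read-out higher numbers stand for weaker inhibition and lower numbers for stronger inhibition. Compound 1 `C#CCOc1ccc(/C=C/C(=O)c2cccc(Br)c2)cc1OC` gives 2900 nM. Compound 2 `C=CCOc1ccc(C=O)cc1OC` gives 5770 nM, a number within the scatter of that of compound 1. Compound 3 `C#CCOc1ccc(/C=C/C(=O)c2ccc(-n3ccnc3)cc2)cc1OC` gives 780 nM, a lower number than compound 1 by a margin beyond the scatter, so compound 1 stands second highest of the three. Compound 4 `C#CCOc1ccc(/C=C/C(=O)c2cccc(OC)c2)cc1OC` has not been measured. It differs from compound 1 in one place: methoxy in place of bromo on an aromatic carbon. Among the measured compounds shown here, no measured pair shows this change, so its effect is unknown from the data. In this assay the expected step is small, a 1.2-fold higher number from compound 1 to compound 4 (0.08 log units; within the scatter), in neither direction beyond the scatter. Compound 4 is thus estimated at 3500 nM, with a range from 1400 nM to 9000 nM.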

Compound 4, half-maximal inhibitory concentration: 1920 nM
Beside the measured number, compound 4's estimate is 1.8-fold (0.26 log units) above it, and the stated range covers the measured number.
By their numbers in this assay, from the lowest: compound 3; then compounds 4, 1 and 2 (each within the scatter of the next, the first and the last beyond it).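

In this assay, the change from 3-bromophenyl to 3-methoxyphenyl gives a 1.5-fold lower number from compound 1 to compound 4 (0.18 log units; within the scatter). Among the compounds shown here, this is the first direct reading at this position, and it shows that replacing bromo with methoxy, a group with one hydrogen-bond acceptor, produces no difference that can be told from the scatter. Nothing available accounts for this outcome. The compounds shown leave open whether an amine or a carboxylic acid on this same aromatic carbon would move the number beyond the scatter.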